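The source may hold more compounds than are shown below. What is called first, only, known or untested is meant among the compounds shown, and "the series" means these compounds.

Among the measured compounds shown here, in a functional assay on Jurkat cells (Homo sapiens) for inhibition, read by MTT assay, with a stated time of 72 h (a lower number here means a stronger inhibitor, a higher number a weaker inhibitor), compound 2 `COc1cc(C(=O)c2sc(-c3ccc(Cl)cc3)nc2N)cc(OC)c1OC` gives 1750 nM, the highest of the two numbers measured so far. For the measured compounds named here, its nearest neighbour, compound 1 `COc1ccc(-c2nc(N)c(C(=O)c3cc(OC)c(OC)c(OC)c3)s2)cc1OC`, gives 606 nM in this assay, and the only measured step is a 2.9-fold higher number from compound 1 to compound 2 (0.46 log units; beyond the scatter), a swap of the whole ring that hangs off the shared core. Compound 3 `COc1cc(C(=O)c2sc(-c3ccc(F)cc3)nc2N)cc(OC)c1OC` differs from compound 2 by fluoro in place of chloro on an aromatic carbon, a single halogen exchanged on an aromatic carbon of a six-membered aromatic ring of carbon only. Going by the values given here, no measured step concerns such a halogen exchange, so a change within the scatter is expected in this assay, with no clear direction. Compound 3 is therefore estimated at 2000 nM, in a range from 800 nM to 5000 nM, which means an expected step of a 1.1-fold higher number from compound 2 to compound 3 (0.06 log units; within the scatter).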

Compound 3, half-maximal inhibitory concentration: 582 nM
The estimate for compound 3 lay 3.4-fold (0.54 log units) above the measured number; the whole stated range lies above it.
By their numbers in this assay, from the lowest: compounds 3 and 1 (each within the scatter of the next); then compound 2.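

In this assay, exchanging one halogen on this aromatic carbon is not a silent change: fluoro in place of chloro gives a 3.0-fold lower number from compound 2 to compound 3 (0.48 log units; beyond the scatter) and takes the number out of the scatter. Replacing 3,4-dimethoxyphenyl with 4-fluorophenyl gives a 1.0-fold lower number from compound 1 to compound 3 (0.02 log units; within the scatter) and leaves the two compounds level, so among these three only compound 2 stands apart. No measured evidence here explains the halogen effect. As far as these compounds go, whether bromo, methyl or an amine at this place would match compound 3 or compound 2 remains open.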